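Second methyl on the sulfonamide nitrogen of a benzoic acid

This account rests on a few compounds, and the source may have more. Where it says the series, first, only, none or still open, it means among the compounds named here.

Measured compounds:
compound 1 `CCCCNc1ccc(C(=O)O)cc1S(N)(=O)=O` gives 6.4%
compound 2 `CCCCNc1ccc(C(=O)O)cc1S(=O)(=O)NC` gives 6.2%

In an assay on HEK293 cells for inhibition of solute carrier family 12 member 2 (Homo sapiens), read by fluorescence, with a stated time of 30 min, tested at 100 uM (a lower number here means a weaker effect, a higher number a stronger effect of the compound at the concentration tested), compound 1 gives 6.4% and compound 2 gives 6.2%; the gap between them, a number 0.2 percentage points lower from compound 1 to compound 2 (within the scatter), lies within the scatter, so the two compounds stand together at the same low level of inhibition and neither can be set above the other. Among the compounds with values here, compound 2 thus occupies the same place as its only measured neighbour.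

Compound 3 `CCCCNc1ccc(C(=O)O)cc1S(=O)(=O)N(C)C` has not been measured. It differs from compound 2 by methyl in place of hydrogen on a sulfonamide nitrogen. Within the data shown here, the one measured step that bears on this change is the earlier one of the same kind, a number 0.2 percentage points lower from compound 1 to compound 2 (within the scatter), which was within the scatter. On that basis no step beyond the scatter is expected in this assay from compound 2 to compound 3, in either direction, and the expected step is a number 0.2 percentage points lower from compound 2 to compound 3 (within the scatter). Compound 3 is therefore estimated to give 6%, with a range from -4% to 16%.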

Compound 3, a percentage reported as inhibition, at one concentration (the size of the read-out at that concentration, not a potency): 15.6%
Compound 3: middle estimate off by 9.6 percentage points, on the low side; measured number inside the range.
By their numbers in this assay, from the lowest: compounds 2, 1 and 3 (each within the scatter of the next).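

Compound 3 shows that this sulfonamide nitrogen can carry two methyl groups, leaving no hydrogen on it, while the read-out in this assay stays within the scatter of both earlier compounds. The earlier pair tested only one methyl, whereas here the same exchange gives a step of greater size, a number 9.4 percentage points higher from compound 2 to compound 3 (within the scatter), and the full change from amino to dimethylamino on the sulfonyl sulfur gives a number 9.2 percentage points higher from compound 1 to compound 3 (within the scatter), yet neither step can be read as a real difference. All three compounds therefore stand together in this assay, and the two methyl exchanges give no basis for ranking them or for claiming a trend with the number of methyl groups; nothing available offers an explanation for the numbers seen.

The compounds shown leave open whether an ethyl group on the sulfonamide nitrogen, or a piperidine or morpholine ring built on that nitrogen, would move the read-out beyond the scatter. They also leave open what an amide or a tetrazole in place of the carboxylic acid, or a longer chain on the amine, would do on the same core.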